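A few compounds are considered here, and "the series" means these few. Any claim that something is new, unique, unknown or untested is made for them only; others in the source may bear on it.

Compound 1 `COc1ccc(/C=C2\Cc3c(cc(OC)c(OC)c3OC)C2=O)cc1[N+](=O)[O-]` shows the lowest of the two numbers in a functional assay on PC-3 cells (Homo sapiens) for antiproliferative activity, read by MTT assay, with a stated time of 48 h (a lower number here means a stronger inhibitor of growth, a higher number a weaker inhibitor of growth), with 1560 nM. Compound 2 `COc1cc(/C=C2\Cc3c(cc(OC)c(OC)c3OC)C2=O)cc(OC)c1OC` gives 4990 nM in this assay. Compound 3 `COc1cc2c(c(OC)c1OC)C/C(=C\c1cc(OC)c(OC)c(OC)c1OC)C2=O` yields only a limit of this assay, > 10000 nM. For the measured compounds named here, the one measured step, an at least 2.0-fold higher number from compound 2 to compound 3 (0.30 log units; that floor lies within the scatter), adds a methoxy in place of hydrogen on an aromatic carbon and sits at the limit (the limit of > 10000 nM in this assay, at which 1 of the 3 values shown sits). Compound 4 `COc1ccc(/C=C2\Cc3c(cc(OC)c(OC)c3OC)C2=O)cc1F` differs from compound 1 by fluoro in place of nitro on an aromatic carbon. Going by the values given here, no measured step swaps a nitro for a fluoro, so the measured step gives little guidance on its size or direction. The expected step for this assay is therefore modest, a 1.9-fold higher number from compound 1 to compound 4 (0.28 log units; within the scatter), and compound 4 is estimated at 3000 nM, within a range from 900 nM to 10000 nM.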

Compound 4, concentration for 50% growth inhibition: 277 nM
Compound 4: middle estimate off by 11-fold (1.03 log units), on the high side; measured number below the stated range.
By their numbers in this assay, from the lowest: compound 4; then compound 1; then compound 2. At a limit, above all of these: compound 3.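

For the compounds shown here, replacing nitro with fluoro on this aromatic carbon, ortho to a methoxy group, gives a 5.6-fold lower number from compound 1 to compound 4 (0.75 log units; beyond the scatter) in this assay and is the first measured step at this position. It shows that growth inhibition responds to the group placed here and that nitro is not needed to keep that inhibition. Nothing measured here bears on why the number falls. Going by these compounds, whether an amine, a chloro group or a carboxylic acid at this position would lower or raise the number stays open.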